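Truncating the urea tail of compound 2

The source may report more compounds than this note shows. Statements on the series, on what has been measured and on what is new or still open speak of the compounds shown alone.

Compound 2 `CN1CCC(c2ccc3c(c2)oc(=O)n3C(=O)NCCCCc2ccc(F)cc2)CC1` gives 94 nM in an assay on HEK293 cells for inhibition of acid ceramidase (Homo sapiens), read by fluorescence, with stated times of 10 min and 3 h (a lower number here means a stronger inhibitor, a higher number a weaker inhibitor), numerically the highest of the three values shown, though compound 3 `O=C(NCCCCc1ccccc1)n1c(=O)oc2cc(C3CCCCC3)ccc21` at 89 nM and compound 1 `CC(=O)N1CCC(c2ccc3c(c2)oc(=O)n3C(=O)NCCCCc2ccccc2)CC1` at 64 nM both lie within the scatter of it. Among the compounds with values here, the only single-place step among the measured compounds is a 1.4-fold higher number from compound 1 to compound 3 (0.14 log units; within the scatter), which concerns the substituent on the aromatic carbon, not the tail on the urea nitrogen. Compound 4 `CCOCCNC(=O)n1c(=O)oc2cc(C3CCN(C)CC3)ccc21` alters that tail: ethoxy in place of 2-(4-fluorophenyl)ethyl on a saturated chain carbon, two bonds along the chain from an amide-type nitrogen. Within the data shown here, no measured pair covers an exchange of this kind, and the shared core has not been tested with a tail this short, so the expectation is weakly founded and the range wide. Compound 4 is expected to give 600 nM, with a range from 100 nM to 5000 nM. The expected step of a 6.4-fold higher number from compound 2 to compound 4 (0.81 log units; beyond the scatter) thus points toward a weaker inhibitor.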

Compound 4, half-maximal inhibitory concentration: 1050 nM
Compound 4: the middle estimate sits 1.8-fold (0.24 log units) below what was measured; the range from low to high includes it.
By their numbers in this assay, from the lowest: compounds 1, 3 and 2 (each within the scatter of the next); then compound 4.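

Within the data shown here, on the tail of the urea nitrogen, the exchange gives an 11-fold higher number from compound 2 to compound 4 (1.05 log units; beyond the scatter) in this assay and is the first step beyond the scatter. Among these compounds, this position therefore does not tolerate every replacement, although the one step on the aromatic carbon stayed within the scatter. No measured evidence accounts for this step.

A single exchange cannot separate loss of the aromatic ring from the shorter chain or the added oxygen. A hexyl chain, with no ring and no oxygen, or a benzyl group would help to separate them.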